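This account rests on a few compounds, and the source may have more. Where it says the series, first, only, none or still open, it means among the compounds named here.

In a functional assay on DU-145 cells (Homo sapiens) for antiproliferative activity, read by MTT assay, with a stated time of 48 h (a lower number here means a stronger inhibitor, a higher number a weaker inhibitor), three esters sharing one core have been read. Compound 1 `C/C(=C\CC/C(C)=C/CC[C@@H]1[C@@]2(C)CCC(=O)C(C)(C)[C@H]2CC[C@@]1(C)O)CC/C=C(\C)C(=O)OCc1cn(-c2ccccc2Br)nn1` gives > 150000 nM, which is a limit of the assay. Compound 2 `C/C(=C\CC/C(C)=C/CC[C@@H]1[C@@]2(C)CCC(=O)C(C)(C)[C@H]2CC[C@@]1(C)O)CC/C=C(\C)C(=O)OCc1cn(-c2cccc([N+](=O)[O-])c2)nn1` gives > 150000 nM, which is likewise a limit. Among the compounds with values here, compound 3 `C/C(=C\CC/C(C)=C/CC[C@@H]1[C@@]2(C)CCC(=O)C(C)(C)[C@H]2CC[C@@]1(C)O)CC/C=C(\C)C(=O)OCc1cn(-c2ccccc2)nn1` gives 95500 nM, the only actual number among the three.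

Compound 4 `C/C(=C\CC/C(C)=C/CC[C@@H]1[C@@]2(C)CCC(=O)C(C)(C)[C@H]2CC[C@@]1(C)O)CC/C=C(\C)C(=O)OCc1cn(-c2ccccc2Cl)nn1` departs from compound 3 by one change: chloro in place of hydrogen on an aromatic carbon, ortho to a large group. Within the data shown here, two measured steps bear on this. The closer one is an at least 1.5-fold lower number from compound 1 to compound 3 (0.19 log units; that floor lies within the scatter), where hydrogen replaces bromo, and it is read here in reverse. The other is an at least 1.5-fold lower number from compound 2 to compound 3 (0.19 log units; that floor lies within the scatter), where hydrogen replaces nitro. Both are floors that lie within the scatter, so they give only a weak hint of direction.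

A small rise in the number is therefore expected, with the estimated move being a 1.4-fold higher number from compound 3 to compound 4 (0.13 log units; within the scatter). Compound 4 is expected at about 130000 nM, with an estimated range from 75000 nM to 220000 nM.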

Compound 4, half-maximal inhibitory concentration: > 150000 nM
Compound 4: a limit, no number (the forecaster's own chance of this, stated with the estimate: 45%); middle value at least 1.1-fold (0.06 log units) away from the limit.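

Chloro in place of hydrogen on the aromatic carbon ortho to a large group gives an at least 1.5-fold higher number from compound 3 to compound 4 (0.19 log units; that floor lies within the scatter), so this step is only a floor and its true size stays hidden. Compound 4 joins compound 1 and compound 2 at the limit, leaving compound 3, with its plain phenyl, as the only ester here with an actual number: the limit of > 150000 nM in this assay, at which 3 of the 4 values shown sit. The steps from compound 1 and from compound 2 to compound 4 cannot be read, so chloro and bromo at this place cannot be told apart.

From the compounds shown here alone, whether a smaller group such as fluoro at the same place would give a readable number stays open. Going by these compounds, it is also open whether an amine or a methoxy group on the phenyl would bring the number below that of compound 3.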